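A few compounds are considered here, and "the series" means these few. Any claim that something is new, unique, unknown or untested is made for them only; others in the source may bear on it.

Of the compounds shown here, three sharing one core have been measured in an assay on HEK293 cells for displacement of a labelled ligand from NPC1-like intracellular cholesterol transporter 1 (Homo sapiens); a lower number here means a stronger inhibitor, a higher number a weaker inhibitor. Compound 1 `CCOC(=O)C1CCN(C(=O)CN2CN(c3ccccc3)C3(CCN(C(=O)c4ccc(C5CCCCC5)cc4)CC3)C2=O)CC1` gives 900 nM, compound 2 `NC(=O)C1CCCN(C(=O)CN2CN(c3ccccc3)C3(CCN(C(=O)c4ccc(C5CCCCC5)cc4)CC3)C2=O)C1` gives 3100 nM, and compound 3 `O=C(CN1CN(c2ccccc2)C2(CCN(C(=O)c3ccc(C4CCCCC4)cc3)CC2)C1=O)NCCCCO` gives 10300 nM. Compound 3 thus stands highest of the three numbers: the step of an 11-fold higher number from compound 1 to compound 3 (1.06 log units; beyond the scatter) is large, and the step of a 3.3-fold higher number from compound 2 to compound 3 (0.52 log units; beyond the scatter) is modest, while the step of a 3.4-fold higher number from compound 1 to compound 2 (0.54 log units; beyond the scatter) separates the two stronger compounds from each other.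

Compound 4 `CCOC(=O)C1CCCN(C(=O)CN2CN(c3ccccc3)C3(CCN(C(=O)c4ccc(C5CCCCC5)cc4)CC3)C2=O)C1` differs from compound 3 in one place: 3-(ethoxycarbonyl)piperidin-1-yl in place of (4-hydroxybutyl)amino on a carbonyl carbon. The change undoes the loss of the ring seen in the step from compound 1 to compound 3, and brings back an ethoxycarbonyl group on a piperidine, now named 3-(ethoxycarbonyl)piperidin-1-yl rather than the 4-(ethoxycarbonyl)piperidin-1-yl of compound 1. For the measured compounds named here, the steps that bear on this are an 11-fold higher number from compound 1 to compound 3 (1.06 log units; beyond the scatter) and a 3.3-fold higher number from compound 2 to compound 3 (0.52 log units; beyond the scatter), both beyond the scatter and both pointing the same way. Compound 4 is therefore expected to give a lower number than compound 3 in this assay, by a step of roughly a 6.9-fold lower number from compound 3 to compound 4 (0.84 log units; beyond the scatter), somewhere between what compound 1 and compound 2 showed. For compound 4 the estimate is 1500 nM, with a range from 600 nM to 4000 nM.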

Compound 4, half-maximal inhibitory concentration: 4200 nM
The estimate for compound 4 lay 2.8-fold (0.45 log units) below the measured number; measured number outside the range, above it.
By their numbers in this assay, from the lowest: compound 1; then compounds 2 and 4 (each within the scatter of the next); then compound 3.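

In this assay, 3-(ethoxycarbonyl)piperidin-1-yl in place of 4-(ethoxycarbonyl)piperidin-1-yl gives a 4.7-fold higher number from compound 1 to compound 4 (0.67 log units; beyond the scatter), so at this carbonyl carbon the result depends on where the ethoxycarbonyl group sits on the piperidine, not only on its presence. With the substituent named at 3 on the piperidine, ethoxy in place of amino gives a 1.4-fold higher number from compound 2 to compound 4 (0.13 log units; within the scatter), so the ester and the primary amide cannot be told apart here, and the difference between compound 1 and compound 2 can no longer be read simply as ester against amide. The piperidine ester still improves on the open chain, with a 2.5-fold lower number from compound 3 to compound 4 (0.39 log units; beyond the scatter), but this recovers only part of the distance to compound 1, and the step changes the ring and the ethoxycarbonyl group together, so their shares cannot be separated.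

On these data alone, whether a 4-carbamoylpiperidin-1-yl group would keep the number of compound 1, or whether a carboxylic acid on the piperidine would be tolerated at either place, remains open. Nothing available explains why these differences arise.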